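A few compounds are considered here, and "the series" means these few. Any claim that something is new, unique, unknown or untested is made for them only; others in the source may bear on it.

Measured compounds:
Compound 1, `C#Cc1cccc(Nc2ncnc3cc(OCCCCn4ccnc4[N+](=O)[O-])c(OC)cc23)c1`, gives 590 nM in a functional assay on HT-29 cells (Homo sapiens) for inhibition, read by sulforhodamine B assay, with a stated time of 72 h; on this read-out higher numbers stand for weaker inhibition and lower numbers for stronger inhibition.
Compound 2, `C#Cc1cccc(Nc2ncnc3cc(OCCCCCn4ccnc4[N+](=O)[O-])c(OC)cc23)c1`, gives 280 nM.
Compound 3, `COc1cc2c(Nc3ccc(OCc4cccc(F)c4)c(Cl)c3)ncnc2cc1OCCCCCn1ccnc1[N+](=O)[O-]`, gives 5040 nM.

The change (2-nitro-1H-imidazol-1-yl)methyl in place of 2-nitro-1H-imidazol-1-yl on a saturated chain carbon, four bonds along the chain from an oxygen on an aromatic ring is the only difference within the first pair, and it brought a 2.1-fold lower number from compound 1 to compound 2 (0.32 log units; beyond the scatter). How the core of compound 3 differs from that of compound 1 is not broken down here; the values alone show that compound 3 gives the highest number of the three.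

Compound 4, `COc1cc2c(Nc3ccc(OCc4cccc(F)c4)c(Cl)c3)ncnc2cc1OCCCCCCn1ccnc1[N+](=O)[O-]`, differs from compound 3 by (2-nitro-1H-imidazol-1-yl)methyl in place of 2-nitro-1H-imidazol-1-yl on a saturated chain carbon, five bonds along the chain from an oxygen on an aromatic ring. This is the same kind of change as in the first pair, not the same: there the place was four bonds along the chain from an oxygen on an aromatic ring, here it is five. A step of about a 1.6-fold lower number from compound 3 to compound 4 (0.20 log units; within the scatter) is expected, resting on the earlier pair because the related change gave a 2.1-fold lower number from compound 1 to compound 2 (0.32 log units; beyond the scatter) on a different core. Compound 4 is therefore estimated at 3200 nM in this assay, with a likely range from 1200 nM to 8500 nM.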

Compound 4, half-maximal inhibitory concentration: > 50000 nM
Compound 4: a limit, no number; the forecaster's own chance of this, stated with the estimate: 5%; middle value at least 15-fold (1.19 log units) away from the limit.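

In this assay, (2-nitro-1H-imidazol-1-yl)methyl in place of 2-nitro-1H-imidazol-1-yl gave an at least 9.9-fold higher number from compound 3 to compound 4 (0.99 log units; beyond the scatter), opposite in direction to the earlier step, so the change does not carry from one core to the other here: the same change on two cores in this assay, a 2.1-fold lower number (0.32 log units; beyond the scatter) from compound 1 to compound 2 and an at least 9.9-fold higher number (0.99 log units; beyond the scatter) from compound 3 to compound 4, at least 20-fold (1.32 log units) apart, beyond the scatter of two such steps. Going by these compounds, for compound 4, > 50000 nM is a limit of the assay and not a number, so the exact size of this step stays unknown. For the compounds shown here, with only two pairs, this shows that the outcome of the change differs on these two cores, but not which part of the cores matters or how the change would behave on any other core.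

The compounds shown leave open how a longer chain would read on the core of compound 1 and how a shorter chain would read on the core of compound 3. They also leave open whether an amine in place of 2-nitro-1H-imidazol-1-yl would follow the same course.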